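The source may hold more compounds than are shown below. What is called first, only, known or untested is meant among the compounds shown, and "the series" means these compounds.

Measured so far in a physicochemical assay for solubility, using the shake flask method, in simulated intestinal fluid, measured as kinetic solubility, with a stated time of 2 h, at 25 degrees C, at pH 6.5; on this read-out lower numbers stand for lower solubility and higher numbers for higher solubility:

- compound 1, `Cc1nc(C(N)=O)c(N)c2c1C(=O)N(Cc1ccccc1)C2=O`: compound 1 gives < 5000 nM, which is a limit of the assay and not a number.
- compound 2, `Cc1nc(-c2nc(C(F)(F)F)no2)c(N)c2c1C(=O)N(Cc1ccccc1)C2=O`: compound 2 gives < 5000 nM, also a limit.
- compound 3, `Cc1noc(-c2nc(C)c3c(c2N)C(=O)N(Cc2ccc(F)cc2)C3=O)n1`: compound 3 gives < 5000 nM, again a limit.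

Every value shown rests at the same point, (the limit of < 5000 nM in this assay, at which 3 of the 3 values shown sit). Among the measured compounds shown here, the only step between neighbours that differ in one place, a step that the two limits leave unreadable from compound 1 to compound 2, is hidden by the two limits, so its size cannot be read. Compound 3 stands at that limit with no number of its own, and the two further values shown are limits as well, so nothing separates compound 3 from them in this assay.

Compound 4, `Cc1noc(-c2nc(C)c3c(c2N)C(=O)N(Cc2ccc(Br)cc2)C3=O)n1`, differs from compound 3 by bromo in place of fluoro on an aromatic carbon. For the measured compounds named here, no measured step bears on this change: the unreadable step concerns another position, and compound 3 has no measured neighbour of its own. Going by the values given here, what is known is only that all three compounds fall at the limit, (the limit of < 5000 nM in this assay, at which 3 of the 3 values shown sit). The expectation for compound 4 is therefore that this assay again returns a limit rather than a number, and the expected step that the limit leaves unreadable from compound 3 to compound 4 is stated only as a working guess. Compound 4 is estimated at 2000 nM, within 500 nM to 6000 nM.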

Compound 4, solubility: < 5000 nM
Compound 4: only a limit was reported (the forecaster's own chance of this, stated with the estimate: 80%); the middle value does not contradict the limit.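

In this assay compound 4 gives < 5000 nM and this is a limit of the assay, not a number, so no step can be read from compound 3 to compound 4. The compounds shown leave open the size of every step among them, including bromo in place of fluoro on an aromatic carbon, since all rest at one point: the limit of < 5000 nM in this assay, at which 4 of the 4 values shown sit.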